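Trifluoromethyl in Place of Fluoro on the Aromatic Ring

The source may hold more compounds than are shown below. What is called first, only, known or untested is meant among the compounds shown, and "the series" means these compounds.

Compound 1, `Cc1ccc(S(=O)(=O)N2N=C(c3ccc(N4CCN(C)CC4)cc3)CC2c2ccc(N(C)C)cc2)cc1`: 10.7%
Compound 2, `CN1CCN(c2ccc(C3=NN(S(=O)(=O)c4ccc(F)cc4)C(c4ccc(N(C)C)cc4)C3)cc2)CC1`: 15.7%

Among the compounds with values here, in a functional assay on MDA-MB-231 cells (Homo sapiens) for inhibition, read by sulforhodamine B assay, tested at 10 uM (a higher number here means more inhibition at the concentration tested (going by the name of the read-out), a lower number less inhibition), compound 2 gives 15.7%, the top of the two numbers, with compound 1 nearest; yet the only measured step, a number 5 percentage points higher from compound 1 to compound 2 (within the scatter), lies within the scatter, so the two compounds cannot be told apart. Compound 3, `CN1CCN(c2ccc(C3=NN(S(=O)(=O)c4ccc(C(F)(F)F)cc4)C(c4ccc(N(C)C)cc4)C3)cc2)CC1`, differs from compound 2 by trifluoromethyl in place of fluoro on an aromatic carbon. That earlier step also swapped one small group for another on the same aromatic carbon and stayed within the scatter, so the step from compound 2 to compound 3 is expected to be a number 1.3 percentage points higher from compound 2 to compound 3 (within the scatter), none beyond the scatter. Compound 3 is therefore estimated at 17%, between 4% and 34%.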

Compound 3, a percentage reported as inhibition, at one concentration (the size of the read-out at that concentration, not a potency): 12.1%
For compound 3 the middle estimate is 4.9 percentage points above the measured one; measured number inside the range.
By their numbers in this assay, from the lowest: compounds 1, 3 and 2 (each within the scatter of the next).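

The change to trifluoromethyl gives a number 3.6 percentage points lower from compound 2 to compound 3 (within the scatter) and the change from methyl to trifluoromethyl gives a number 1.4 percentage points higher from compound 1 to compound 3 (within the scatter) in this assay on this aromatic carbon. Methyl, fluoro and trifluoromethyl therefore cannot be told apart at this position, even though trifluoromethyl brings four heavy atoms where fluoro brings one. Nothing measured here explains this result. Still open, as far as these compounds go, is whether a different kind of group at this position, such as an amine or a carboxylic acid, would give a number beyond the scatter.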